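Swapping the aryl group on the pyrrolidine core

This account rests on a few compounds, and the source may have more. Where it says the series, first, only, none or still open, it means among the compounds named here.

Measured so far:
compound 1, `CC[C@@]1(O)C[C@H](C(=O)Nc2ccc(-n3cccc(C)c3=O)cc2F)N(C(=O)Nc2ccc(Cl)cc2)C1`, 5.2 h
compound 2, `CCO[C@]1(CC)C[C@H](C(=O)Nc2ccc(-n3ccccc3=O)cc2F)N(C(=O)Nc2ccc(Cl)cc2)C1`, 1.4 h
compound 3, `Cc1ccc([C@@]2(O)C[C@H](C(=O)Nc3ccc(-n4ccccc4=O)cn3)N(C(=O)Nc3ccc(Cl)cc3)C2)cc1`, 1.8 h

All three were tested in an in vivo ADME assay on the whole organism for metabolic stability, with Rattus norvegicus as the target, using cassette dosing; a higher number here means that the compound lasts longer, a lower number that the compound disappears faster. Compound 3, with its value of 1.8 h, sits in the middle of the three numbers. Its value and that of compound 2 lie within the usual scatter of each other, so nothing separates them. Compound 1, at 5.2 h, lasts clearly longer than compound 3, a gap beyond the scatter.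

Compound 4, `O=C(Nc1ccc(-n2ccccc2=O)cn1)[C@H]1C[C@](O)(c2ccccc2Cl)CN1C(=O)Nc1ccc(Cl)cc1`, has not been measured. It differs from compound 3 in one place: 2-chlorophenyl in place of 4-methylphenyl on a saturated ring carbon. Among the measured compounds shown here, no measured pair shows this exact swap, so there is no step to lean on. The change keeps the size of the group and adds no donor or acceptor, and the expectation is a step from compound 3 to compound 4 of a 1.1-fold higher number from compound 3 to compound 4 (0.05 log units; within the scatter), no larger than the scatter, in no firm direction. Compound 4 is therefore estimated at 2 h, with a likely range from 0.9 h to 4.5 h.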

Compound 4, half-life: 2.9 h
Compound 4: middle estimate off by 1.5-fold (0.16 log units), on the low side; measured number inside the range.
By their numbers in this assay, from the lowest: compounds 2, 3, 4 and 1 (each within the scatter of the next, the first and the last beyond it).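

In this assay, putting 2-chlorophenyl in place of 4-methylphenyl on the saturated ring carbon gives a 1.6-fold higher number from compound 3 to compound 4 (0.21 log units; within the scatter). Among the compounds shown here, this is the first direct reading at this position, and it shows that these two aryl groups can be exchanged there without the half-life leaving the usual scatter. No measurement shown here offers an explanation for this small step.

The compounds shown leave open whether a group of a different kind at this position, such as a phenyl ring carrying an amine or a carboxylic acid, would give a step beyond the scatter. They also leave open whether the same swap would read the same way if the rest of the molecule were different.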